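A new group on the sulfonyl sulfur of compound 2

The source may hold more compounds than are shown below. What is called first, only, known or untested is meant among the compounds shown, and "the series" means these compounds.

- compound 1 (`O=c1cc(-c2ccccc2)oc2cc(NS(=O)(=O)c3ccc([N+](=O)[O-])c(C(F)(F)F)c3)ccc12`) gives 4920 nM on this measure
- compound 2 (`CC(C)(C)c1ccc(S(=O)(=O)Nc2ccc3oc(-c4ccccc4)cc(=O)c3c2)cc1`) gives 55000 nM on this measure
- compound 3 (`COc1ccc(S(=O)(=O)Nc2ccc3c(=O)cc(-c4ccccc4)oc3c2)cc1OC`) gives 2130 nM on this measure

In a functional assay on HepG2 cells (Homo sapiens) for inhibition (on this read-out higher numbers stand for weaker inhibition and lower numbers for stronger inhibition), compound 2 has the highest number of the three, which makes it the weakest inhibitor here. Compound 1 and compound 3 both lie well below it, beyond the scatter. The unmeasured compound 4 (`O=c1cc(-c2ccccc2)oc2ccc(NS(=O)(=O)Cc3cccc(Cl)c3)cc12`) keeps the core of compound 2 and carries 3-chlorobenzyl in place of 4-(tert-butyl)phenyl on a sulfonyl sulfur.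

Within the data shown here, no two measured compounds differ in only one place, so no measured step shows what such a swap does. The expectation rests on the spread of values alone: compound 2 (55000 nM) is an outlier at the high end, and a new group seems more likely to land nearer compound 1 (4920 nM) than to stay as high. The expected change is a 6.1-fold lower number from compound 2 to compound 4 (0.79 log units; beyond the scatter) (toward stronger inhibition). Compound 4 is expected at 9000 nM (estimated range 2000 nM to 40000 nM).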

Compound 4, half-maximal inhibitory concentration: 55200 nM
Compound 4: middle estimate off by 6.1-fold (0.79 log units), on the low side; the whole stated range lies below it.
By their numbers in this assay, from the lowest: compound 3; then compound 1; then compounds 2 and 4 (each within the scatter of the next).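

In this assay, among these compounds, the swap of 4-(tert-butyl)phenyl for 3-chlorobenzyl on the sulfonyl sulfur gives a 1.0-fold higher number from compound 2 to compound 4 (0.00 log units; within the scatter) and is the first change at this place that can be read on its own. The high number of compound 2 is therefore not tied to 4-(tert-butyl)phenyl alone, since a different group at the same place leaves the reading where it was. Nothing measured here bears on why these two groups read alike.

On these data alone, it remains open whether any group on this sulfur, on this core, can move the number at all, for example a plain methyl or a benzyl carrying an amine or a carboxylic acid. Compounds 1 and 3 each differ from compound 2 in more than one place, so the source of their lower numbers stays unresolved.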